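Cytotoxicity of Hydroxyamino Pyranone Amides in Huh-7 Cells

The source may report more compounds than this note shows. Statements on the series, on what has been measured and on what is new or still open speak of the compounds shown alone.

Compound 1 `O=C(Nc1ccccc1)c1c(NO)cc(-c2ccc(Cl)cc2)oc1=O`: 11000 nM
Compound 2 `O=C(Nc1ccc(F)cc1)c1c(NO)cc(-c2ccccc2)oc1=O`: > 20000 nM
Compound 3 `Cc1ccc(NC(=O)c2c(NO)cc(-c3ccc(F)cc3)oc2=O)cc1`: > 20000 nM

In an ADME assay on Huh-7 cells (Homo sapiens) for cytotoxicity, read by a luciferase reporter and WST assay, with a stated time of 3 days (a lower number here means that less compound is tolerated, a higher number that more compound is tolerated), compound 1 gives 11000 nM. For compound 2 the value > 20000 nM is a limit of the assay, not a number. For compound 3 the value > 20000 nM is likewise a limit. Compound 2 therefore stands at the limit of > 20000 nM in this assay, at which 2 of the 3 values shown sit, and only compound 1 yields an actual number. Compound 4 `CNC(=O)c1c(NO)cc(-c2ccccc2)oc1=O`, not yet measured, differs from compound 2 by methyl in place of 4-fluorophenyl on an amide-type nitrogen. Within the data shown here, no step between two measured compounds is available, so the scale of such a change is unknown. The estimated step that the limit leaves unreadable from compound 2 to compound 4 is expected to be none beyond the scatter. Compound 4 is expected to give 25000 nM, within 10000 nM to 60000 nM, most probably reported again as a limit.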

Compound 4, half-maximal cytotoxic concentration: > 20000 nM
Compound 4 ended at the assay's limit (the forecaster's own chance of this, stated with the estimate: 75%); the middle value lies beyond the limit too.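

Among these compounds, compound 2 and compound 4 both end at a limit and not at a number, so no step between them can be read: the limit of > 20000 nM in this assay, at which 3 of the 4 values shown sit.

The compounds shown leave open how far methyl in place of 4-fluorophenyl on an amide-type nitrogen changes the tolerated concentration.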